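A few compounds are considered here, and "the series" means these few. Any claim that something is new, unique, unknown or untested is made for them only; others in the source may bear on it.

Compound 2 `Cc1ccc(-c2csc(N/N=C/c3ccc(Cl)cc3Cl)n2)cc1` is a close relative of compound 1 `Fc1ccc(-c2csc(N/N=C/c3ccc(Cl)cc3Cl)n2)cc1` and compound 3 `COC(=O)c1cc(-c2csc(N/N=C/c3ccc(Cl)cc3Cl)n2)ccc1OCc1ccccc1`. In a functional assay, read by spectrophotometry, with a stated time of 15 min, tested at 60 ug/mL (on this read-out lower numbers stand for a weaker effect and higher numbers for a stronger effect at the one concentration tested), compound 2 gives 83.2%, the second highest of the three numbers; compound 1 gives 92.4%, and compound 3 gives 66.3%, which lies beyond the scatter below compound 2. The unmeasured compound 4 `COc1ccc(-c2csc(N/N=C/c3ccc(Cl)cc3Cl)n2)cc1` carries methoxy in place of methyl on an aromatic carbon. For the measured compounds named here, the one measured step at the same place is a number 9.2 percentage points lower from compound 1 to compound 2 (within the scatter), a swap that did not move the read-out beyond the scatter. Going by the values given here, no step that brings in methoxy has been measured, so a change of similar small size is expected: a number 3.2 percentage points lower from compound 2 to compound 4 (within the scatter). Compound 4 is expected to give about 80% in this assay, with a range from 65% to 92%.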

Compound 4, a percentage reported as inhibition, at one concentration (the size of the read-out at that concentration, not a potency): 82.8%
The estimate for compound 4 lay 2.8 percentage points below the measured number; the measured number falls inside the stated range.
By their numbers in this assay, from the lowest: compound 3; then compounds 4, 2 and 1 (each within the scatter of the next).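

Replacing methyl with methoxy on the phenyl ring gives a number 0.4 percentage points lower from compound 2 to compound 4 (within the scatter) in this assay, and replacing fluoro with methoxy at the same place gives a number 9.6 percentage points lower from compound 1 to compound 4 (within the scatter). This position therefore accepts three different groups, including methoxy with its added oxygen, without a shift beyond the scatter. Nothing available explains why these swaps change so little.

As far as these compounds go, whether an amine, a carboxylic acid or a longer chain such as butoxy would also leave the read-out unchanged remains open. A single concentration also leaves open whether compound 1, compound 2 and compound 4 would differ in the size of their effect at any other concentration.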